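A chloro substituent tested on a shared spiro core

The compounds below may be only part of what the source reports. "The series", "measured", "known", "first", "only" and "open" are said of these compounds alone.

Compound 1 `CN1C(=O)C2(C(C#N)=C(N)Oc3cc4oc(-c5ccccc5)cc(=O)c4c(O)c32)c2ccccc21`: in a functional assay on PC-3 cells (Homo sapiens) for antiproliferative activity, read by MTT assay, with a stated time of 48 h (on this read-out lower numbers stand for stronger inhibition and higher numbers for weaker inhibition), compound 1 gives > 50000 nM, a limit of the assay.
Compound 2 `CC(C)(C)OC(=O)CN1C(=O)C2(C(C#N)=C(N)Oc3cc4oc(-c5ccccc5)cc(=O)c4c(O)c32)c2ccccc21`: in this assay compound 2 gives > 50000 nM, also a limit.
Compound 3 `N#CC1=C(N)Oc2cc3oc(-c4ccccc4)cc(=O)c3c(O)c2C12C(=O)Nc1ccccc12`: in this assay compound 3 gives > 50000 nM, again a limit.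

Compound 3 therefore stands only at a limit, and all three measured values sit at the same limit (the limit of > 50000 nM in this assay, at which 3 of the 3 values shown sit). Compound 4 `N#CC1=C(N)Oc2cc3oc(-c4ccccc4)cc(=O)c3c(O)c2C12C(=O)Nc1cc(Cl)ccc12` differs from compound 3 by chloro in place of hydrogen on an aromatic carbon. The measured steps all concern the amide-type nitrogen in the ring, not an aromatic carbon: a step that the two limits leave unreadable from compound 1 to compound 2, a step that the two limits leave unreadable from compound 1 to compound 3 and a step that the two limits leave unreadable from compound 2 to compound 3 cannot be read because every end sits at the limit (the limit of > 50000 nM in this assay, at which 3 of the 3 values shown sit). They give no direction for the chloro change. Because compound 3 gives > 50000 nM in this assay, a limit, compound 4 is expected to show a step that the limit leaves unreadable from compound 3 to compound 4, nothing beyond the scatter. The estimate for compound 4 is 60000 nM, between 20000 nM and 200000 nM.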

Compound 4, half-maximal inhibitory concentration: 25700 nM
The estimate for compound 4 lay 2.3-fold (0.37 log units) above the measured number, within the range that was stated.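

Among the compounds shown, compound 4 alone gives a number rather than a limit: the limit of > 50000 nM in this assay, at which 3 of the 4 values shown sit.

In this assay, chloro in place of hydrogen on an aromatic carbon gives an at least 1.9-fold lower number from compound 3 to compound 4 (0.28 log units; that floor lies within the scatter), so this aromatic position, unlike the amide-type nitrogen, yields a readable result. The value of compound 3 is only a limit, so the step has a floor but no full size, and that floor does not pass the scatter.

On these data alone, whether bromo or methoxy on the same carbon would also give a number remains open. So does whether chloro would give one alongside methyl on the amide-type nitrogen.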